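A few compounds are considered here, and "the series" means these few. Any claim that something is new, unique, unknown or untested is made for them only; others in the source may bear on it.

Measured in a functional assay on A549/CDDP cells (Homo sapiens) for antiproliferative activity, read by MTT assay, with a stated time of 72 h; on this read-out lower numbers stand for stronger inhibition and higher numbers for weaker inhibition:
- compound 1 `Cc1nc(C)c(/C=C/C(=O)/C=C/c2ccccc2O)nc1C`: 3900 nM
- compound 2 `COc1cccc(/C=C/C(=O)/C=C/c2nc(C)c(C)nc2C)c1O`: 2190 nM

Within the data shown here, compound 1, at 3900 nM, lies within the scatter of compound 2, the only other compound with a number. Compound 3 `Cc1nc(C)c(/C=C/C(=O)/C=C/c2ccc(F)cc2)nc1C` has not yet been measured. It keeps the core of compound 1 and differs as follows: 4-fluorophenyl in place of 2-hydroxyphenyl on a double-bonded chain carbon bound to a double-bonded chain carbon. Among the measured compounds shown here, the one measured step is a 1.8-fold lower number from compound 1 to compound 2 (0.25 log units; within the scatter). It is methoxy in place of hydrogen on an aromatic carbon, and it leaves the hydroxy group in place. For the measured compounds named here, it therefore bears only loosely on this change, and no measured compound shows what losing that hydroxy group does. With no evidence for a shift in either direction, no change beyond the scatter is expected in this assay. The expected size is a 1.2-fold higher number from compound 1 to compound 3 (0.06 log units; within the scatter). For compound 3 the estimated value is 4500 nM, with an expected range from 1500 nM to 13000 nM.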

Compound 3, half-maximal inhibitory concentration: 7440 nM
Compound 3: middle estimate off by 1.7-fold (0.22 log units), on the low side, within the range that was stated.
By their numbers in this assay, from the lowest: compounds 2, 1 and 3 (each within the scatter of the next, the first and the last beyond it).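

Exchanging the 2-hydroxyphenyl for 4-fluorophenyl on a double-bonded chain carbon bound to a double-bonded chain carbon gives a 1.9-fold higher number from compound 1 to compound 3 (0.28 log units; within the scatter) in this assay. Among these compounds, this is the first measured change at this place, and it shows that the hydroxy group, which compound 2 also keeps, can be lost along with the arrival of fluorine without a step beyond the scatter. Nothing measured here explains this result or ties it to any property of either group.

The step removes the hydroxy group and adds the fluorine together, so the compounds shown cannot separate the two changes. As far as these compounds go, whether an unsubstituted phenyl, or a phenyl carrying an amine or a carboxylic acid, would move the number beyond the scatter at this place remains open.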